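Sulfamoylpiperazine acetamides: propoxy analogue of compound 2

A few compounds are considered here, and "the series" means these few. Any claim that something is new, unique, unknown or untested is made for them only; others in the source may bear on it.

Two members of the series have a number in an assay on HEK293 cells for inhibition of potassium channel subfamily T member 1 (Homo sapiens), read by thallium flux (a lower number here means a stronger inhibitor, a higher number a weaker inhibitor), so far. Compound 1 `Cc1ccc(Cl)cc1NC(=O)CN1CCN(S(=O)(=O)N2CCC(C)CC2)CC1` carries a methyl on the aromatic carbon; in this assay compound 1 gives > 10000 nM, which is a limit of the assay and not a number (the limit of > 10000 nM in this assay, at which 1 of the 2 values shown sits). Compound 2 `CC1CCN(S(=O)(=O)N2CCN(CC(=O)Nc3cc(Cl)ccc3OCC3CC3)CC2)CC1` carries cyclopropylmethoxy in place of methyl on an aromatic carbon, and in this assay compound 2 gives 7500 nM. Within the data shown here, the step reads an at least 1.3-fold lower number from compound 1 to compound 2 (0.12 log units; that floor lies within the scatter), so compound 2 stands as the only compound of the pair with a measured number, and its value is not far from the limit.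

Compound 3 `CCCOc1ccc(Cl)cc1NC(=O)CN1CCN(S(=O)(=O)N2CCC(C)CC2)CC1` differs from compound 2 by ethyl in place of cyclopropyl on a saturated chain carbon bound to an oxygen on an aromatic ring. Only the step from compound 1 to compound 2 bears on this position, and it changed the number by at most the amount given above, with a floor inside the scatter; no measured step separates cyclopropyl from ethyl on that chain carbon. The expectation for compound 3 is therefore a step of a 1.1-fold higher number from compound 2 to compound 3 (0.03 log units; within the scatter), no larger than the scatter. Compound 3 is estimated at 8000 nM, with a range from 3000 nM to 20000 nM.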

Compound 3, half-maximal inhibitory concentration: 4300 nM
Compound 3: middle estimate off by 1.9-fold (0.27 log units), on the high side; the measured number falls inside the stated range.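

Against the methyl of compound 1, propoxy gives the only step at this position that clears the scatter in this assay: an at least 2.3-fold lower number from compound 1 to compound 3 (0.36 log units; beyond the scatter). That step is a floor, since the value of compound 1, > 10000 nM, is a limit of the assay and not a number: the limit of > 10000 nM in this assay, at which 1 of the 3 values shown sits.

The ring of the cyclopropylmethoxy group is not required for a measured number at this position, as ethyl in place of cyclopropyl gives a 1.7-fold lower number from compound 2 to compound 3 (0.24 log units; within the scatter), which leaves compound 2 and compound 3 unseparated in this assay.

A methoxy or ethoxy group at this place would show whether the oxygen alone or the chain beyond it accounts for the step away from methyl, and a butoxy or longer chain would show whether the number keeps falling as the chain grows. Also open, going by these compounds, is how a chain ending in an amine or a carboxylic acid would read at this position, and whether changes elsewhere on the shared core would move the number further than any change at this position has so far.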